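Enlarging the Hydroxyalkoxy Chain: Expected Microsomal Half-Life

A few compounds are considered here, and "the series" means these few. Any claim that something is new, unique, unknown or untested is made for them only; others in the source may bear on it.

Compound 1, `COCCOc1ccc2c(Oc3ccc(Nc4nccc5[nH]cc(-c6ccc(F)cc6)c(=O)c45)cc3F)ccnc2c1`: 1.73 h
Compound 2, `CC(C)(O)COc1ccc2c(Oc3ccc(Nc4nccc5[nH]cc(-c6ccccc6)c(=O)c45)cc3F)ccnc2c1`: 5.37 h
Compound 3, `O=c1c(-c2ccc(F)cc2)c[nH]c2ccnc(Nc3ccc(Oc4ccnc5cc(OCCO)ccc45)c(F)c3)c12`: 1.51 h

All three compounds share one core and were tested in an ADME assay on microsomes from liver (Rattus norvegicus) for metabolic stability; on this read-out higher numbers stand for a longer-lived compound and lower numbers for a shorter-lived compound. In this assay compound 3 gives 1.51 h, a number that lies within the scatter of compound 1 and well below compound 2. Among the measured compounds shown here, the one measured single-place step, a 1.1-fold lower number from compound 1 to compound 3 (0.06 log units; within the scatter), concerns a different change and offers little guidance here.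

Compound 4, `CC(C)(O)COc1ccc2c(Oc3ccc(Nc4nccc5[nH]cc(-c6ccc(F)cc6)c(=O)c45)cc3F)ccnc2c1`, differs from compound 3 in one place: 1-hydroxy-1-methylethyl in place of hydroxymethyl on a saturated chain carbon bound to an oxygen on an aromatic ring. For the measured compounds named here, compound 2 carries the same 2-hydroxy-2-methylpropoxy chain but differs from compound 3 in a second place as well, so no single step can be drawn from it; compound 2 simply gives 5.37 h.

Because compound 2 with this chain reaches 5.37 h, compound 4 is expected to show a longer half-life than compound 3, a step of a 2.5-fold higher number from compound 3 to compound 4 (0.40 log units; beyond the scatter), beyond the scatter. Compound 4 is estimated at 3.8 h, with a likely range from 1.9 h to 7.5 h.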

Compound 4, half-life: 4.14 h
Estimate against measurement, compound 4: 1.1-fold (0.04 log units) below, and the stated range covers the measured number.
By their numbers in this assay, from the lowest: compounds 3 and 1 (each within the scatter of the next); then compounds 4 and 2 (each within the scatter of the next).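

In this assay, among the compounds shown here, putting 1-hydroxy-1-methylethyl in place of hydroxymethyl on a saturated chain carbon bound to an oxygen on an aromatic ring gives a 2.7-fold higher number from compound 3 to compound 4 (0.44 log units; beyond the scatter), the first reading of this change with nothing else altered. The same group in place of methoxymethyl gives a 2.4-fold higher number from compound 1 to compound 4 (0.38 log units; beyond the scatter), so the branched chain end stands apart from both smaller chain ends shown. Fluoro in place of hydrogen on an aromatic carbon gives no readable difference, a 1.3-fold lower number from compound 2 to compound 4 (0.11 log units; within the scatter), so the two compounds with the branched chain can be treated as level in this measurement.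

Nothing available explains why this chain goes with the higher number. As far as these compounds go, whether an amine, a carboxylic acid or a longer chain at this place would give a similar half-life remains open.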